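A Fluorinated Phenyl Ring in Place of a Chlorinated One

A few compounds are considered here, and "the series" means these few. Any claim that something is new, unique, unknown or untested is made for them only; others in the source may bear on it.

Measured compounds:
compound 1: `Nc1scc(CN2CCN(c3cc(Cl)cc(Cl)c3)CC2)c1C(=O)c1ccc(Cl)cc1` — -1%
compound 2: `Nc1scc(CN2CCN(c3ccc(Cl)cc3F)CC2)c1C(=O)c1ccc(Cl)cc1` — -9.2%
compound 3: `Nc1scc(CN2CCN(c3cccc(C(F)(F)F)c3)CC2)c1C(=O)c1ccc(Cl)cc1` — -8.2%

All three were tested in a functional assay on CHO cells with adenosine receptor A1 (Homo sapiens) as the target, read by cAMP accumulation and immunoassay, with a stated time of 6 min, tested at 0.01 uM; a higher number here means a weaker effect of the compound at the concentration tested, a lower number a stronger effect. Compound 1 stands highest of the three numbers, but only by small margins: the nearest is compound 3, with a number 7.2 percentage points lower from compound 1 to compound 3 (within the scatter), and the furthest is compound 2, with a number 8.2 percentage points lower from compound 1 to compound 2 (within the scatter). The third pair is no different, as a number 1 percentage points higher from compound 2 to compound 3 (within the scatter) shows. In short, the three compounds behave alike within the scatter of this assay.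

Compound 4, `Nc1scc(CN2CCN(c3ccc(F)cc3F)CC2)c1C(=O)c1ccc(Cl)cc1`, is a further member of the same series. It differs from compound 1 in one place:
2,4-difluorophenyl in place of 3,5-dichlorophenyl on an amine nitrogen in a ring

For the measured compounds named here, the steps that bear on this change are those from compound 1 to compound 2 and from compound 1 to compound 3, in which the same 3,5-dichlorophenyl was exchanged for another substituted phenyl on the same ring nitrogen. Both stayed within the scatter. A similar outcome is therefore expected here: no step beyond the scatter in this assay, in either direction.

For compound 4 the value is estimated at -6%, with a range from -20% to 10%. The expected step, a number 5 percentage points lower from compound 1 to compound 4 (within the scatter), is estimated to lie within the scatter.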

Compound 4, a percentage reported as activity, at one concentration (the size of the read-out at that concentration, not a potency): 0%
Estimate against measurement, compound 4: 6 percentage points below; low and high end bracket the measured number.
By their numbers in this assay, from the lowest: compounds 2, 3, 1 and 4 (each within the scatter of the next).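

Replacing both chlorines of the 3,5-dichlorophenyl with the fluorines of 2,4-difluorophenyl on this ring nitrogen gives a number 1 percentage points higher from compound 1 to compound 4 (within the scatter) in this assay, so a phenyl ring carrying only fluorine behaves here like the chlorinated rings. The same holds against the trifluoromethyl ring, with a number 8.2 percentage points higher from compound 3 to compound 4 (within the scatter) as the step. For the compounds shown here, the closest comparison is the single exchange of fluoro for chloro on an aromatic carbon, and a number 9.2 percentage points higher from compound 2 to compound 4 (within the scatter) shows that this one halogen swap also stays inside the noise of the measurement. Nothing available explains why these four phenyl groups read alike.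

Going by these compounds, all four rings carry only halogens or trifluoromethyl, so it remains open how a methoxy group, an amine or a carboxylic acid on the phenyl ring would read. The read-out also comes from one concentration, which leaves any difference in potency among these compounds unresolved.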